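The source may report more compounds than this note shows. Statements on the series, on what has been measured and on what is new or still open speak of the compounds shown alone.

Working notes on the series

Compound 1 `O=C(OC1(C(=O)Nc2ccc([N+](=O)[O-])cc2)CCCCC1)c1ccc(Cl)cc1` gives 10.3 nM in a functional assay on NFS-60 cells (Mus musculus) for inhibition, read by MTT assay, with a stated time of 72 h (on this read-out lower numbers stand for stronger inhibition and higher numbers for weaker inhibition), and stands lowest of the three measured numbers, beyond the scatter from both others. Compound 2 `O=C(/C=C/c1ccccc1)OC1(C(=O)Nc2ccc([N+](=O)[O-])cc2)CCCCC1` gives 50.5 nM in this assay, and compound 3 `O=C(OC1(C(=O)Nc2ccc([N+](=O)[O-])cc2)CCCCC1)c1ccccc1` gives 766 nM in this assay. The steps away from compound 1 are a 4.9-fold higher number from compound 1 to compound 2 (0.69 log units; beyond the scatter) and a 74-fold higher number from compound 1 to compound 3 (1.87 log units; beyond the scatter); between the other two the step is a 15-fold higher number from compound 2 to compound 3 (1.18 log units; beyond the scatter). Compound 4 `CCC(=O)OC1(C(=O)Nc2ccc([N+](=O)[O-])cc2)CCCCC1` differs from compound 1 by ethyl in place of 4-chlorophenyl on a carbonyl carbon. Both measured changes to the 4-chlorophenyl group raised the number: replacing it by 2-phenylethenyl gave a 4.9-fold higher number from compound 1 to compound 2 (0.69 log units; beyond the scatter), and taking away only the chloro gave the large step of a 74-fold higher number from compound 1 to compound 3 (1.87 log units; beyond the scatter). Ethyl removes the entire 4-chlorophenyl, including the chloro whose loss alone was large, so a large rise in this assay is expected, with nothing in the data pointing to a fall. The step expected is a 58-fold higher number from compound 1 to compound 4 (1.77 log units; beyond the scatter). Compound 4 is therefore estimated at 600 nM in this assay, with a range from 120 nM to 3000 nM.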

Compound 4, half-maximal inhibitory concentration: 6.4 nM
Beside the measured number, compound 4's estimate is 94-fold (1.97 log units) above it; measured number outside the range, below it.
By their numbers in this assay, from the lowest: compounds 4 and 1 (each within the scatter of the next); then compound 2; then compound 3.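

In this assay, an aromatic ring on this carbonyl carbon proves dispensable: the step of a 1.6-fold lower number from compound 1 to compound 4 (0.21 log units; within the scatter) puts ethyl level with 4-chlorophenyl, so the chloro matters only within the phenyl-bearing pair, not for the position as a whole. Among these four compounds, compound 3 is the one that stands apart, with a 120-fold lower number from compound 3 to compound 4 (2.08 log units; beyond the scatter) for ethyl in place of phenyl, while the step of a 7.9-fold lower number from compound 2 to compound 4 (0.90 log units; beyond the scatter) shows that the small chain also outdoes 2-phenylethenyl, so the number does not follow the size of the group in any simple order. No measurement at hand explains why plain phenyl alone falls so far behind.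

Open, going by these compounds, is whether a longer chain, such as butyl, or a chain carrying an amine or a carboxylic acid, would keep the number of compound 4. Equally open, on these data alone, is whether a fluoro or methoxy group in place of the chloro would match compound 1.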